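Dithiocarbamate benzamide series: amine swap at the thiocarbonyl

A few compounds are considered here, and "the series" means these few. Any claim that something is new, unique, unknown or untested is made for them only; others in the source may bear on it.

Measured so far, in a functional assay on MGC-803 cells (Homo sapiens) for antiproliferative activity, read by CCK-8 assay, with a stated time of 72 h, tested at 2 uM; a lower number here means a weaker effect, a higher number a stronger effect of the compound at the concentration tested:
compound 1 `Nc1ccccc1NC(=O)c1ccc(CSC(=S)N2CCN(c3ccccc3)CC2)cc1`: 42.3%
compound 2 `Nc1ccccc1NC(=O)c1ccc(CSC(=S)N2CCc3ccccc32)cc1`: 44%
compound 3 `Nc1ccccc1NC(=O)c1ccc(CSC(=S)N2CCN(c3ccc(F)cc3)CC2)cc1`: 18.8%

Compound 2 gives the highest of the three numbers. Its nearest neighbour is compound 1, within the scatter of it, so no order between compound 2 and compound 1 can be claimed; compound 3 sits well below, beyond the scatter. Going by the values given here, the one step through a single change is a number 23.5 percentage points lower from compound 1 to compound 3 (beyond the scatter); it concerns the aromatic ring on the piperazine and says nothing directly about the amine swap considered here.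

Compound 4 `CC1CCN(C(=S)SCc2ccc(C(=O)Nc3ccccc3N)cc2)CC1` differs from compound 2 by 4-methylpiperidin-1-yl in place of 2,3-dihydro-1H-indol-1-yl on a thiocarbonyl carbon. Among the compounds with values here, no measured step covers this replacement. What the series does show is that compound 1 and compound 2, which carry two different amines on the same thiocarbonyl carbon, give values within the scatter of each other; the amine replaced there is not the one entering here, so this is only a loose hint. On that basis the expected step of a number 6 percentage points lower from compound 2 to compound 4 (within the scatter) is small, of either sign, and most likely within the scatter. Compound 4 is estimated at 38% in this assay, with a range from 22% to 52%.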

Compound 4, a percentage reported as inhibition, at one concentration (the size of the read-out at that concentration, not a potency): 28.1%
Estimate against measurement, compound 4: 9.9 percentage points above, and the stated range covers the measured number.
By their numbers in this assay, from the lowest: compounds 3 and 4 (each within the scatter of the next); then compounds 1 and 2 (each within the scatter of the next).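

At the thiocarbonyl carbon, the first single-place step among these amines in this assay is a number 15.9 percentage points lower from compound 2 to compound 4 (beyond the scatter), so 4-methylpiperidin-1-yl in place of 2,3-dihydro-1H-indol-1-yl is not a neutral exchange, which the within-scatter values of compound 1 and compound 2 gave no sign of. The entering group has a six-membered non-aromatic ring and no aromatic ring, whereas the leaving group has a five-membered non-aromatic ring and a six-membered aromatic ring, and this one step cannot separate those differences or show which of them carries the drop. No measurement on hand accounts for the step.

From the compounds shown here alone, the role of the methyl group remains open, since a comparison with unsubstituted piperidin-1-yl would isolate it, while morpholin-4-yl would test an oxygen atom in the same ring position. An open-chain amine such as diethylamino on the thiocarbonyl carbon would show whether any ring is needed here, and a tetrahydroquinolin-1-yl group would test whether the aromatic ring keeps the effect when the non-aromatic ring is enlarged.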